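The compounds below may be only part of what the source reports. "The series", "measured", "known", "first", "only" and "open" are said of these compounds alone.

Working notes on the series, all read in a functional assay on cells (Homo sapiens) for cytotoxicity, read by MTT assay, with a stated time of 24 h; on this read-out higher numbers stand for weaker inhibition and lower numbers for stronger inhibition. Compound 1 (`CCCCCCCCCCCCCCNC(=O)[C@H](CO)/N=C/c1ccc(OC)cc1`) gives 28100 nM, compound 2 (`CCCCCCCCCCCCCCNC(=O)[C@H](CO)/N=C/c1ccccc1[N+](=O)[O-]`) gives 21700 nM, and compound 3 (`CCCCCCCCCCCCCCNC(=O)[C@H](CO)/N=C/c1ccccc1`) gives 7670 nM, the lowest of the three numbers. Compound 4 (`CCCCCCCCCCCCCCNC(=O)[C@H](CO)/N=C/c1cccc(O)c1`) is the next to read: hydroxy in place of hydrogen on an aromatic carbon, phenyl to 3-hydroxyphenyl (hydroxy in place of hydrogen on an aromatic carbon).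

Within the data shown here, two measured steps bear on this change, each modest and beyond the scatter: with methoxy replaced by hydrogen, a 3.7-fold lower number from compound 1 to compound 3 (0.56 log units; beyond the scatter), and with nitro replaced by hydrogen, a 2.8-fold lower number from compound 2 to compound 3 (0.45 log units; beyond the scatter). The third step, a 1.3-fold lower number from compound 1 to compound 2 (0.11 log units; within the scatter), lies within the scatter. Among these three compounds, both ring substituents go with a higher number than the unsubstituted ring, and no compound goes against this. Hydroxy itself has not been measured here, so the expectation is loose: a modest rise, opposite in direction to those two steps and similar in size. The expected step is a 1.8-fold higher number from compound 3 to compound 4 (0.26 log units; within the scatter). Compound 4 is estimated at 14000 nM, with an expected range of 5500 nM to 32000 nM.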

Compound 4, half-maximal inhibitory concentration: 32600 nM
Beside the measured number, compound 4's estimate is 2.3-fold (0.37 log units) below it; the measured number lies above the stated range.
By their numbers in this assay, from the lowest: compound 3; then compounds 2, 1 and 4 (each within the scatter of the next).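

Among these compounds, compound 4 shows that hydroxy at this place, meta to a large group, also goes with a rise in this assay, with a 4.3-fold higher number from compound 3 to compound 4 (0.63 log units; beyond the scatter), so all three substituted rings now read higher than the unsubstituted ring of compound 3, and no compound among the four goes against this. The substituted rings do not separate from one another, with a 1.5-fold higher number from compound 2 to compound 4 (0.18 log units; within the scatter) and a 1.2-fold higher number from compound 1 to compound 4 (0.06 log units; within the scatter), both within the scatter, so 3-hydroxyphenyl, 2-nitrophenyl and 4-methoxyphenyl cannot be ranked on these numbers. No supporting data bear on the reason for the rise.

On these data alone, it remains open whether any substituent on this ring goes with a higher number, or whether a small group such as fluoro or an amine would stay close to compound 3. Also open, as far as these compounds go, is how a longer chain would shift these numbers.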